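Swapping the dimethoxyphenyl arm for a trifluoromethylphenyl arm

A few compounds are considered here, and "the series" means these few. Any claim that something is new, unique, unknown or untested is made for them only; others in the source may bear on it.

Of the compounds shown here, three have been measured in a functional assay on BGC-823 cells (Homo sapiens) for antiproliferative activity, read by MTT assay, tested at 1 uM; on this read-out lower numbers stand for a weaker effect and higher numbers for a stronger effect at the one concentration tested. Compound 1, with the structure `COc1ccc(C2OC(c3cc(OC)c(OC)c(OC)c3)=NN2C(C)=O)c(OC)c1`, gives 6.3%, the top figure of the three. Compound 3, with the structure `COc1cccc(/C=N/NC(=O)c2cc(OC)c(OC)c(OC)c2)c1OC`, gives -0.1% in this assay, a figure whose gap to compound 1 lies within the usual scatter of such measurements, so the two cannot be told apart. Compound 2, with the structure `COc1cc(C(=O)N/N=C/c2ccc(Cl)c([N+](=O)[O-])c2)cc(OC)c1OC`, gives -5.8% in this assay, and its gap to compound 1 lies beyond the scatter. All three figures are small, so none of the compounds shows more than a faint effect at the single concentration tested.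

The next compound, compound 4, has the structure `COc1cc(C2=NN(C(C)=O)C(c3ccc(C(F)(F)F)cc3)O2)cc(OC)c1OC`. Compared with compound 1 the change is 4-(trifluoromethyl)phenyl in place of 2,4-dimethoxyphenyl on a saturated ring carbon; the rest of the shared core is untouched. Within the data shown here, no pair of measured compounds differs in only this one place, so nothing measured tells how large a step this swap brings. Given how small every figure is so far, the expected step from compound 1 to compound 4 in this assay is a number 1.7 percentage points higher from compound 1 to compound 4 (within the scatter), not beyond the scatter in either direction. Compound 4 is therefore estimated to give 8% in this assay, with a likely range from -8% to 25%.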

Compound 4, a percentage reported as inhibition, at one concentration (the size of the read-out at that concentration, not a potency): 4.2%
Beside the measured number, compound 4's estimate is 3.8 percentage points above it; low and high end bracket the measured number.
By their numbers in this assay, from the lowest: compounds 2, 3, 4 and 1 (each within the scatter of the next, the first and the last beyond it).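

In this assay, putting 4-(trifluoromethyl)phenyl in place of 2,4-dimethoxyphenyl on the saturated ring carbon gives a number 2.1 percentage points lower from compound 1 to compound 4 (within the scatter), the first step read between two compounds that differ in one place only. At the single concentration tested, this position therefore takes an arm with 0 hydrogen-bond acceptors instead of one with 2, with no difference that can be told from the usual spread of repeats, although both figures are so small that the comparison is between two faint effects. Nothing measured alongside this result offers an explanation for it.

From the compounds shown here alone, what remains open is whether any group on this ring carbon can raise the figure clearly beyond the scatter, for instance a phenyl arm carrying an amine or a carboxylic acid. It is equally unclear whether the acetyl group on the ring nitrogen matters, which a longer chain such as butanoyl in its place could test, and whether the two arms would still look alike at a higher concentration, where a stronger or weaker effect might be told apart.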